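Replacing fluoro with trifluoromethyl on the aryl sulfonamide

This account rests on a few compounds, and the source may have more. Where it says the series, first, only, none or still open, it means among the compounds named here.

Four compounds share one core, a bicyclic alcohol carrying a sulfonamide. Compound 1 `O=S(=O)(c1ccc2c(c1)C(O)CC(C1CCOCC1)O2)N1CCC(c2ccccc2)CC1` links the sulfonyl group to a saturated nitrogen ring bearing a phenyl group, while compound 2 `CC(C)CN(c1ccccc1F)S(=O)(=O)c1ccc2c(c1)C(O)CC(C1CCOCC1)O2` and compound 3 `CCc1ccc(N(CC(C)C)S(=O)(=O)c2ccc3c(c2)C(O)C[C@@H](C2CCOCC2)O3)cc1` carry an isobutyl chain and a substituted phenyl ring on the sulfonamide nitrogen. In a physicochemical assay for lipophilicity, at pH 7.4 (a lower number here means a more polar compound, a higher number a more lipophilic compound), compound 1 gives 2.63. In this assay compound 2 gives 3.39, the second highest of the three measured values, clearly above compound 1 and clearly below compound 3. In this assay compound 3, which carries an ethyl group on its phenyl ring, gives 4.12.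

Compound 4 `CC(C)CN(c1ccccc1C(F)(F)F)S(=O)(=O)c1ccc2c(c1)C(O)CC(C1CCOCC1)O2` has not been measured. It differs from compound 2 in one place: trifluoromethyl in place of fluoro on an aromatic carbon. Going by the values given here, no measured pair shows this exact exchange, so the expectation rests on the measured compounds as a whole. Compound 3 carries more carbon on its phenyl ring than compound 2 does. The step from compound 2 to compound 4 is expected to be a number 0.71 log units higher from compound 2 to compound 4 (beyond the scatter), beyond the scatter and upward, because compound 3 gives 4.12. Compound 4 is therefore estimated at 4.1, with a range from 3.7 to 4.5.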

Compound 4, distribution coefficient: 4.14
The estimate for compound 4 lay 0.04 log units below the measured number; low and high end bracket the measured number.
By their numbers in this assay, from the lowest: compound 1; then compound 2; then compounds 3 and 4 (each within the scatter of the next).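

In this assay, putting trifluoromethyl in place of fluoro on an aromatic carbon, ortho to a large group, gives a number 0.75 log units higher from compound 2 to compound 4 (beyond the scatter). Going by these compounds alone, this is the first step that can be read for a single change: the three earlier compounds differ from one another in more than one place, so none of them could tie a shift in the number to one group. It shows that this position is not indifferent to the exchange, since swapping this one group, with the rest of the molecule unchanged, moves the number by more than the usual scatter, although nothing measured here accounts for the size of the step.

From the compounds shown here alone, a single exchange cannot show a trend, so how a nitrile, a methoxy group, an amine or a carboxylic acid in place of fluoro would move the number remains open. Also open, going by these compounds, is whether the 2-fluorophenyl to 2-(trifluoromethyl)phenyl exchange gives a step of similar size when the rest of the molecule is different.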